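This account rests on a few compounds, and the source may have more. Where it says the series, first, only, none or still open, it means among the compounds named here.

Compound 1 `O=C(/C=C\Nc1ccc(C(F)(F)F)cc1)c1cn(-c2ccccc2)nc1-c1ccc(F)cc1` is reported only as a limit in a functional assay on HT-29 cells (Homo sapiens) for antiproliferative activity, read by MTT assay, with a stated time of 48 h (on this read-out higher numbers stand for weaker inhibition and lower numbers for stronger inhibition), where compound 1 gives > 50000 nM. In this assay compound 2 `O=C(/C=C\Nc1ccc(O)cc1)c1cn(-c2ccccc2)nc1-c1ccc(F)cc1` gives 1900 nM, and compound 3 `COc1ccc(N/C=C\C(=O)c2cn(-c3ccccc3)nc2-c2ccc(F)cc2)cc1` gives 3200 nM, which is the higher of these two numbers, with compound 2 within the scatter of it. The change from compound 3 to compound 4 `COc1ccc(N/C=C\C(=O)c2cn(-c3ccccc3)nc2-c2ccc(Cl)cc2)cc1` is chloro in place of fluoro on an aromatic carbon. Going by the values given here, none of the measured steps touches this ring: an at least 26-fold lower number from compound 1 to compound 2 (1.42 log units; beyond the scatter) and an at least 15-fold lower number from compound 1 to compound 3 (1.19 log units; beyond the scatter) replace the trifluoromethyl on the other aromatic ring, and a 1.7-fold higher number from compound 2 to compound 3 (0.23 log units; within the scatter) alters the oxygen there. With no guide, compound 4 is expected to give 3000 nM, with a range from 1200 nM to 8000 nM. That estimate means an expected step of a 1.1-fold lower number from compound 3 to compound 4 (0.03 log units; within the scatter), within the scatter.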

Compound 4, half-maximal inhibitory concentration: 8930 nM
The estimate for compound 4 lay 3.0-fold (0.47 log units) below the measured number; the whole stated range lies below it.
By their numbers in this assay, from the lowest: compounds 2 and 3 (each within the scatter of the next); then compound 4. At a limit, above all of these: compound 1.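

Until now only the other aromatic ring had varied, and this step shows that the 4-fluorophenyl ring also affects the result: going to 4-chlorophenyl gives a 2.8-fold higher number from compound 3 to compound 4 (0.45 log units; beyond the scatter) in this assay. Even a swap of one halogen atom for another at this place moves the number beyond the scatter, though modestly. Nothing measured here explains this step.

From the compounds shown here alone, it remains open how a bromo group, a methyl group or an amine would behave at this place. Whether the same swap would give a similar step with the hydroxy group of compound 2 on the other ring is also unresolved.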